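This account rests on a few compounds, and the source may have more. Where it says the series, first, only, none or still open, it means among the compounds named here.

Compound 1 `NC(=O)CC[C@H](NC(=O)CN(c1ncnc2c1ncn2C1CCCCO1)C1CC1)C(=O)OCc1ccccc1` gives 10.7% in a functional assay on the whole organism (Tail, strain ICR) with Mus musculus as the target, in the tail flick test, with a stated time of 150 min, at a dose of 25 umol/kg by the oral route (a lower number here means a weaker effect, a higher number a stronger effect of the compound at the dose given), the second highest of three numbers: compound 2 `CC[C@H](C)[C@H](NC(=O)CN(c1nc(Cl)nc2[nH]cnc12)C1CC1)C(=O)O` gives 6.71%, within the scatter of compound 1, while compound 3 `O=C(O)CC[C@H](NC(=O)CN(c1nc(Cl)nc2[nH]cnc12)C1CC1)C(=O)O` gives 29.5%, beyond it. Among the compounds with values here, the only measured step, a number 22.8 percentage points higher from compound 2 to compound 3 (beyond the scatter), exchanges the group on the saturated chain carbon bound to the amide-type nitrogen and the carbonyl carbon. Compound 4 `C[C@H](NC(=O)CN(c1ncnc2c1ncn2C1CCCCO1)C1CC1)C(=O)OCc1ccccc1` differs from compound 1 by hydrogen in place of carbamoylmethyl on a saturated chain carbon, two bonds along the chain from an amide-type nitrogen and a carbonyl carbon. That change also removes a group from the chain, but what leaves and what enters differ from the measured step, so it gives no direct guide; the shared core of compound 1 stays. The expected step, a number 1.3 percentage points higher from compound 1 to compound 4 (within the scatter), is no change beyond the scatter. Compound 4 is estimated at 12%, between 0% and 30%.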

Compound 4, a percentage reported as activity, at one dose (the size of the read-out at that dose, not a potency): 6.01%
Estimate against measurement, compound 4: 6 percentage points above, within the range that was stated.
By their numbers in this assay, from the lowest: compounds 4, 2 and 1 (each within the scatter of the next); then compound 3.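

Hydrogen in place of carbamoylmethyl on this saturated chain carbon gives a number 4.7 percentage points lower from compound 1 to compound 4 (within the scatter) in this assay. On the core of compound 1, carbamoylmethyl at this position is therefore not needed for the read-out at this dose, and its loss leaves no change beyond the scatter. Nothing available explains this result.

Still open, from the compounds shown here alone, is whether a chain ending in an amine or a hydroxymethyl group at this carbon would move the number beyond the scatter on this core.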